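Compound 3 and its (methylsulfanyl)methyl analogue

This account rests on a few compounds, and the source may have more. Where it says the series, first, only, none or still open, it means among the compounds named here.

Compound 1 `COc1cc(-c2nc3ccccc3s2)ccc1OCC(=O)NNC(=O)CN[C@@H](CS)C(=O)O`: 1230 nM
Compound 2 `CCOC(=O)[C@@H](NCC(=O)NNC(=O)COc1ccc(-c2nc3ccccc3s2)cc1OC)[C@@H](C)CC`: 1950 nM
Compound 3 `CCOC(=O)[C@H](CS)NCC(=O)NNC(=O)COc1ccc(-c2nc3ccccc3s2)cc1OC`: 2880 nM

All three values come from a functional assay on MCF7 cells (Homo sapiens) for inhibition, read by MTT assay, with a stated time of 3 days; on this read-out lower numbers stand for stronger inhibition and higher numbers for weaker inhibition. Compound 3 stands close to compound 2, with a 1.5-fold higher number from compound 2 to compound 3 (0.17 log units; within the scatter). It stands further from compound 1, with a 2.3-fold higher number from compound 1 to compound 3 (0.37 log units; beyond the scatter).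

The unmeasured compound 4 `CCOC(=O)[C@H](CCSC)NCC(=O)NNC(=O)COc1ccc(-c2nc3ccccc3s2)cc1OC` differs from compound 3 by a single change: (methylsulfanyl)methyl in place of sulfanyl on a saturated chain carbon, two bonds along the chain from an amine nitrogen and a carbonyl carbon. Cut one bond further out, the same difference reads sulfanylmethyl to 2-(methylsulfanyl)ethyl.

Among the compounds with values here, no measured step makes exactly this change. The closest evidence is the step from compound 2 to compound 3 already given, where sulfanylmethyl takes the place of sec-butyl on the carbon bound to the amine nitrogen and the carbonyl carbon, and that step stayed within the scatter. The step of a 1.6-fold higher number from compound 1 to compound 2 (0.20 log units; within the scatter) also stayed within the scatter, although it altered that side chain and the ethyl group together. The modest step to compound 3 from compound 1 concerns ethyl in place of hydrogen, and compound 4 keeps that ethyl, so it says little here.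

No step beyond the scatter is therefore expected in this assay, and the estimate is a 1.2-fold lower number from compound 3 to compound 4 (0.08 log units; within the scatter). Compound 4 is expected at 2400 nM, with an estimated range from 1150 nM to 5000 nM.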

Compound 4, half-maximal inhibitory concentration: 1760 nM
Estimate against measurement, compound 4: 1.4-fold (0.13 log units) above, and the stated range covers the measured number.
By their numbers in this assay, from the lowest: compounds 1, 4, 2 and 3 (each within the scatter of the next, the first and the last beyond it).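

In this assay, sulfanyl gives way to (methylsulfanyl)methyl with no step beyond the scatter (a 1.6-fold lower number from compound 3 to compound 4 (0.21 log units; within the scatter)), and 2-(methylsulfanyl)ethyl and sec-butyl also stay within it (a 1.1-fold lower number from compound 2 to compound 4 (0.04 log units; within the scatter)), so the three chains on this saturated chain carbon in compounds 2, 3 and 4, only one of them ending in a sulfanyl, now all lie within the scatter of one another. The step from the carboxylic acid of compound 1 to the ethyl ester of compound 3 lay beyond the scatter (a 2.3-fold higher number from compound 1 to compound 3 (0.37 log units; beyond the scatter)), but the listed step to compound 4, which also carries an ethyl ester, lies within it (a 1.4-fold higher number from compound 1 to compound 4 (0.16 log units; within the scatter)), so an ethyl ester does not by itself set a compound apart from compound 1. No measurement offered here explains why these chains give such similar numbers.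

From the compounds shown here alone, it remains open whether a chain ending in an amine, a phenyl ring or a longer thioether on this carbon would also stay within the scatter. Going by these compounds, the effect of a carboxylic acid in place of the ethyl ester of compound 4 also remains open.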